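Clearance notes on the step from compound 3 to compound 4

The source may hold more compounds than are shown below. What is called first, only, known or untested is meant among the compounds shown, and "the series" means these compounds.

Compound 1 `O=C(Nc1ccccc1)c1cnc(NCc2c(F)ccc3c2CCO3)n2cnnc12` gives 14 mL.min-1.g-1 in an ADME assay on microsomes from liver (Homo sapiens) for metabolic stability, read by LC-MS, using NADPH, with stated times of 5 min and 30 min, tested at 1 uM (on this read-out higher numbers stand for fast clearance and lower numbers for slow clearance), on the shared core. Compound 2 `CN(c1ncco1)c1cnc(NCc2c(F)ccc3c2CCO3)n2cnnc12` gives 11 mL.min-1.g-1 there, and compound 3 `O=C1c2ccccc2CN1c1cnc(NCc2c(F)ccc3c2CCO3)n2cnnc12` gives 13 mL.min-1.g-1 there as well. Compound 3 stands within the scatter of both other compounds, with a 1.1-fold lower number from compound 1 to compound 3 (0.03 log units; within the scatter) and a 1.2-fold higher number from compound 2 to compound 3 (0.07 log units; within the scatter) as its steps, so these numbers give it no rank.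

Compound 4 `Fc1ccc2c(c1CNc1ncc(Oc3ccccc3)c3nncn13)CCO2` differs from compound 3 by a group of 7 heavy atoms (6 carbon, 1 oxygen; one six-membered aromatic ring of carbon only) in place of a group of 10 heavy atoms (8 carbon, 1 nitrogen, 1 oxygen; one five-membered non-aromatic ring with 1 hetero atom, one six-membered aromatic ring of carbon only), on an aromatic carbon and so carries phenoxy on that aromatic carbon, para to a large group. All three measured steps exchange the group at this same aromatic carbon, and the third, a 1.3-fold lower number from compound 1 to compound 2 (0.10 log units; within the scatter) as well, stays within the scatter. Going by the values given here, these steps are the only guide to the new exchange, although no measured compound carries phenoxy, and the range is kept wide for that reason. No step beyond the scatter is expected in this assay for this exchange, and a 1.1-fold higher number from compound 3 to compound 4 (0.03 log units; within the scatter) is the estimated size. Compound 4 is estimated at 14 mL.min-1.g-1 with an expected range from 7 mL.min-1.g-1 to 28 mL.min-1.g-1 as its span.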

Compound 4, intrinsic clearance in microsomes: 18 mL.min-1.g-1
Compound 4: the middle estimate sits 1.3-fold (0.11 log units) below what was measured; measured number inside the range.
By their numbers in this assay, from the lowest: compounds 2, 3, 1 and 4 (each within the scatter of the next).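

Phenoxy is the first group on this aromatic carbon, para to a large group, that carries no nitrogen: it brings only carbon and oxygen, and no carbonyl. Even so, in this assay the exchange stays within the scatter against each of the other three compounds (a 1.4-fold higher number from compound 3 to compound 4 (0.14 log units; within the scatter); a 1.6-fold higher number from compound 2 to compound 4 (0.21 log units; within the scatter); a 1.3-fold higher number from compound 1 to compound 4 (0.11 log units; within the scatter)), so the earlier finding now extends beyond nitrogen-bearing groups, and the four compounds cannot be ranked on this read-out. No measurement shown bears on why the read-out holds so flat across these exchanges.

On these data alone, all four groups at this position carry an aromatic ring, so it remains open whether a group without one, such as a primary amine, a carboxylic acid or a plain alkyl chain, would give a step beyond the scatter. The large group para to this position is the same in all four compounds, which leaves its share in the clearance unresolved and gives no indication of whether an exchange there would move the number more than any exchange seen here.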